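A few compounds are considered here, and "the series" means these few. Any claim that something is new, unique, unknown or untested is made for them only; others in the source may bear on it.

Measured in an ADME assay on TZM cells (Homo sapiens) for cytotoxicity, read by XTT assay, with a stated time of 4 days; a lower number here means that less compound is tolerated, a higher number that more compound is tolerated:
- compound 1 `Cc1cc(CCC#N)cc(C)c1Oc1cc(Nc2ccc(C#N)cc2)c(N)cc1C(=O)O`: 14300 nM
- compound 2 `Cc1cc(CO)cc(C)c1Oc1cc(Nc2ccc(C#N)cc2)c(N)cc1CO`: 15900 nM
- compound 3 `CC(=O)CCc1cc(C)c(Oc2cc(Nc3ccc(C#N)cc3)c(N)cc2C(F)(F)F)c(C)c1`: 11100 nM

In this assay, compound 1 stands level with compound 2 and compound 3, as all three values lie within the usual scatter of one another. Compound 4 `Cc1cc(CCC#N)cc(C)c1Oc1cc(Nc2ccc(C#N)cc2)c(N)cc1C(=O)NN` keeps the core of compound 1 and changes one place: aminoamino in place of hydroxy on a carbonyl carbon. Among the measured compounds shown here, no measured pair shows this change on its own, so the expectation starts from compound 1 at 14300 nM, with no step beyond the scatter. The expected result is a 1.2-fold lower number from compound 1 to compound 4 (0.08 log units; within the scatter). The estimate for compound 4 is 12000 nM, with an expected range of 4500 nM to 30000 nM.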

Compound 4, half-maximal cytotoxic concentration: > 22700 nM
Compound 4 ended at the assay's limit; the forecaster's own chance of this, stated with the estimate: 12%; middle value at least 1.8-fold (0.27 log units) from the limit.
By their numbers in this assay, from the lowest: compounds 3, 1 and 2 (each within the scatter of the next). At a limit, above all of these: compound 4.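

Aminoamino in place of hydroxy on a carbonyl carbon is the only change here seen on its own, and it gives an at least 1.5-fold higher number from compound 1 to compound 4 (0.20 log units; that floor lies within the scatter) in this assay. The cells therefore tolerate compound 4 at least as well as compound 1, although this step cannot yet be told apart from the scatter. The reading for compound 4 is a limit, not a number: the limit of > 22700 nM in this assay, at which 1 of the 4 values shown sits.

Still open, going by these compounds, is whether a plain amide or a methyl ester on this carbonyl carbon would read the same way. On these data alone, whether aminoamino behaves alike with the trifluoromethyl or hydroxymethyl groups of the other compounds also remains unknown.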